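This account rests on a few compounds, and the source may have more. Where it says the series, first, only, none or still open, it means among the compounds named here.

Compound 1 `OCCNC(=S)Nc1ccccc1` — >= 200000 nM
Compound 2 `COc1cc(NC(=S)Nc2ccccc2)cc(OC)c1OC` — 15200 nM
Compound 3 `O=C(O)c1ccc(NC(=S)NCc2ccccc2)cc1O` — 8100 nM

Of the compounds shown here, three built on a shared core have been measured in a functional assay on RAW264.7 cells (Mus musculus) for inhibition, read by Griess assay, with a stated time of 24 h; a higher number here means a weaker inhibitor, a lower number a stronger inhibitor. Compound 2 gives 15200 nM in this assay. Compound 3 gives 8100 nM in this assay. For compound 1 the assay reports only a limit, >= 200000 nM, and not a number. Compound 1 therefore stands at the limit of >= 200000 nM in this assay, at which 1 of the 3 values shown sits, the weakest position the readout can express, and nothing more precise about its potency is available. For the measured compounds named here, no pair among the three measured compounds differs in a single place, so no measured step can be drawn on for comparison.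

The unmeasured compound 4 `OCCN(CCO)C(=S)Nc1ccccc1` is reached from compound 1 by a single change: 2-hydroxyethyl in place of hydrogen on an amide-type nitrogen. Going by the values given here, the only anchor for compound 4 is the limit seen for compound 1, and no measured step shows what this kind of change does here. The step of a number no higher from compound 1 to compound 4 (the limit leaves the size open) is therefore expected to be none beyond the scatter, with compound 4 most likely staying at the limit. Compound 4 is estimated at 200000 nM, within a range from 60000 nM to 600000 nM.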

Compound 4, half-maximal inhibitory concentration: 50700 nM
For compound 4 the middle estimate is 3.9-fold (0.60 log units) above the measured one, and the stated range ends above it.
By their numbers in this assay, from the lowest: compounds 3 and 2 (each within the scatter of the next); then compound 4. At a limit, above all of these: compound 1.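

In this assay, 2-hydroxyethyl in place of hydrogen on the amide-type nitrogen, whose other neighbours are a saturated chain carbon and the thiocarbonyl carbon, gives an at least 3.9-fold lower number from compound 1 to compound 4 (0.59 log units; beyond the scatter). For the compounds shown here, this is the first measured step, and it shows that this nitrogen can carry the added group with inhibition retained and a number that can be read. Its full size stays unknown because compound 1 gives only a limit, not a number: the limit of >= 200000 nM in this assay, at which 1 of the 4 values shown sits.

The compounds shown leave open whether this step belongs to 2-hydroxyethyl in particular or would also follow from another group on this nitrogen, such as a methyl, a longer chain ending in a hydroxyl, or a chain carrying an amine or a carboxylic acid. Going by these compounds alone, whether the same change would act in the same direction on compound 2 or compound 3 also stays unanswered, and no measured step links either of them to compound 4.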